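Notes on an isopropyl-to-cyclopentyl swap in the series

The compounds below may be only part of what the source reports. "The series", "measured", "known", "first", "only" and "open" are said of these compounds alone.

Measured so far in a functional assay on HepG2 cells (Homo sapiens) for antiproliferative activity, read by CCK-8 assay, with a stated time of 72 h, tested at 8 uM; a lower number here means a weaker effect, a higher number a stronger effect of the compound at the concentration tested:
Compound 1 `Nc1ccccc1NC(=O)/C=C/c1ccc(COCNc2nc(Nc3cccc(Cl)c3)c3ncn(C4CCCC4)c3n2)cc1`: 14.8%
Compound 2 `CC(C)n1cnc2c(Nc3cccc(Cl)c3)nc(NCOCc3ccc(/C=C/C(=O)Nc4ccccc4N)cc3)nc21`: 49.9%
Compound 3 `CC(C)n1cnc2c(NCc3ccc(C(=O)Nc4ccccc4N)cc3)nc(Cl)nc21`: 74.4%

Compound 3 stands highest of the three in this assay, beyond the scatter against both others. Compound 2 and compound 1 differ in one place, (cyclopentyl in place of isopropyl on an aromatic nitrogen), and this change gave a number 35.1 percentage points lower from compound 2 to compound 1 (beyond the scatter). The difference between the core of compound 2 and the core of compound 3 is not broken down here.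

Compound 4 `Nc1ccccc1NC(=O)c1ccc(CNc2nc(Cl)nc3c2ncn3C2CCCC2)cc1` is not yet measured. It differs from compound 3 by cyclopentyl in place of isopropyl on an aromatic nitrogen, the same change at the same place as seen once before. Within the data shown here, with only one measured instance of this change, on a different core, the expectation is tentative. Compound 4 is expected to give about 45% in this assay, with an estimated range from 25% to 65%. Among the measured compounds shown here, the estimated step of a number 29.4 percentage points lower from compound 3 to compound 4 (beyond the scatter) is expected to be downward because the one measured instance of this change gave a number 35.1 percentage points lower from compound 2 to compound 1 (beyond the scatter).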

Compound 4, a percentage reported as inhibition, at one concentration (the size of the read-out at that concentration, not a potency): 74.9%
For compound 4 the middle estimate is 29.9 percentage points below the measured one; measured number above the stated range.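

Cyclopentyl in place of isopropyl on an aromatic nitrogen gives a number 0.5 percentage points higher from compound 3 to compound 4 (within the scatter) in this assay, so the large drop seen on the other core does not recur here. The size of this step therefore depends on the core it is made on: the same change on two cores in this assay, a number 35.1 percentage points lower (beyond the scatter) from compound 2 to compound 1 and a number 0.5 percentage points higher (within the scatter) from compound 3 to compound 4, 35.6 percentage points apart, beyond the scatter of two such steps. Two pairs do not show which feature of the cores accounts for the gap, and they give no rule for predicting this change on a further core.

The compounds shown leave open how a smaller group such as methyl, or a larger one such as cyclohexyl, would behave on that nitrogen. They also leave open whether a longer chain there would follow either of the two steps.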